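The compounds below may be only part of what the source reports. "The series", "measured", "known", "first", "only" and "open" are said of these compounds alone.

In a functional assay on PC-3 cells (Homo sapiens) for inhibition, read by sulforhodamine B assay, with a stated time of 48 h (on this read-out lower numbers stand for stronger inhibition of growth and higher numbers for weaker inhibition of growth), compound 2 `C=C1CC[C@@H]2[C@](C)(COC(C)=O)[C@H](OC(C)=O)CC[C@@]2(C)[C@H]1CC(Nc1ccc(S(=O)(=O)Nc2ncccn2)cc1)C1=CCOC1=O` gives 2110 nM. Among the measured compounds shown here, only one other number exists: compound 1 `C=C1CC[C@@H]2[C@](C)(COC(C)=O)[C@H](OC(C)=O)CC[C@@]2(C)[C@H]1CC(Nc1ccc(S(=O)(=O)Nc2cc(C)on2)cc1)C1=CCOC1=O` gives 1980 nM, and the two lie within the scatter of each other, the step of a 1.1-fold higher number from compound 1 to compound 2 (0.03 log units; within the scatter) being flat. Compound 3 `C=C1CC[C@@H]2[C@](C)(COC(C)=O)[C@H](OC(C)=O)CC[C@@]2(C)[C@H]1CC(Nc1ccc(S(=O)(=O)Nc2nccs2)cc1)C1=CCOC1=O` carries 1,3-thiazol-2-yl in place of pyrimidin-2-yl on a sulfonamide nitrogen. For the measured compounds named here, the single step that bears on such an exchange on the sulfonamide nitrogen showed no shift beyond the scatter, so none is expected here either, the estimated step being a 1.1-fold lower number from compound 2 to compound 3 (0.02 log units; within the scatter). Compound 3 is therefore expected to give about 2000 nM, with a range from 900 nM to 4500 nM.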

Compound 3, concentration for 50% growth inhibition: 7740 nM
For compound 3 the middle estimate is 3.9-fold (0.59 log units) below the measured one; the measured number lies above the stated range.
By their numbers in this assay, from the lowest: compounds 1 and 2 (each within the scatter of the next); then compound 3.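

In this assay, the sulfonamide nitrogen proves sensitive to the ring it carries: 1,3-thiazol-2-yl gives a 3.7-fold higher number from compound 2 to compound 3 (0.56 log units; beyond the scatter) and a 3.9-fold higher number from compound 1 to compound 3 (0.59 log units; beyond the scatter), whereas the earlier exchange at this place was flat. Ring size alone does not sort these results, since the five-membered 5-methyl-1,2-oxazol-3-yl of compound 1 and the six-membered pyrimidin-2-yl of compound 2 lie within the scatter of each other.

Nothing available explains why 1,3-thiazol-2-yl stands apart. On these data alone, how a pyridin-2-yl group or a simple methyl group on this nitrogen would compare remains open.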